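Notes on compound 4: methyl in place of methoxy

The source may report more compounds than this note shows. Statements on the series, on what has been measured and on what is new or still open speak of the compounds shown alone.

The series is read in a functional assay on C6 cells (Rattus norvegicus) for cytotoxicity, read by MTT assay, with a stated time of 24 h, tested at 100 ug/mL; a higher number here means a weaker effect of the compound at the concentration tested, a lower number a stronger effect. Among the measured compounds shown here, compound 1 `O=C(CSc1nnnn1-c1ccccc1)N/N=c1/scc(-c2ccccc2)n1-c1ccccc1` gives 35.8% and compound 3 `O=C(CSc1nnnn1-c1ccccc1)N/N=c1/scc(-c2ccc(F)cc2)n1-c1ccccc1` gives 35.8%; the one single-place step measured so far, fluoro in place of hydrogen on an aromatic carbon, is no change at the digits printed from compound 1 to compound 3 (within the scatter). Compound 2 `COc1ccc(-c2cs/c(=N/NC(=O)CSc3nnc(C)s3)n2-c2ccccc2)cc1` gives 25.9%, which sits within the scatter of both compound 1 and compound 3, so the three measured numbers cannot be told apart in this assay.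

Compound 4 `Cc1ccc(-c2cs/c(=N/NC(=O)CSc3nnc(C)s3)n2-c2ccccc2)cc1` differs from compound 2 in one place: methyl in place of methoxy on an aromatic carbon. For the measured compounds named here, no measured pair carries a methoxy to methyl exchange, so there is no direct precedent. Going by the values given here, the only step that bears on a small change on an aromatic carbon of a six-membered carbon ring is no change at the digits printed from compound 1 to compound 3 (within the scatter), and it did not move the read-out beyond the scatter. On that basis compound 4 is expected to stay close to compound 2, with the expected step of a number 4.1 percentage points higher from compound 2 to compound 4 (within the scatter) lying within the scatter and in no clear direction. The estimate for compound 4 in this assay is 30%, with a range from 15% to 45%. Among the compounds with values here, the range is kept wide since only one bearing step exists.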

Compound 4, a percentage reported as activity, at one concentration (the size of the read-out at that concentration, not a potency): 31.5%
Estimate against measurement, compound 4: 1.5 percentage points below; the range from low to high includes it.
By their numbers in this assay, from the lowest: compounds 2, 4, 1 and 3 (each within the scatter of the next).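

In this assay, going from 4-methoxyphenyl to 4-methylphenyl gives a number 5.6 percentage points higher from compound 2 to compound 4 (within the scatter), the only step shown at this place, on an aromatic carbon of a six-membered aromatic ring of carbon only, para to a large group. The oxygen and the hydrogen-bond acceptor counted with methoxy can therefore leave this place without a step beyond the scatter at the single concentration tested. With no change at the digits printed from compound 1 to compound 3 (within the scatter), the series now holds two single-place exchanges on an aromatic carbon, on two different side chains, and neither step lies beyond the scatter, although no measurement on hand explains this outcome.

As far as these compounds go, it remains open whether a group of another kind at this place, such as an amine, a carboxylic acid or a longer chain, would give a step beyond the scatter. Also open, from the compounds shown here alone, are whether the exchange from 4-methoxyphenyl to 4-methylphenyl would read the same on the core of compound 1, and whether read-outs at other concentrations would separate compound 2 from compound 4.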